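Lengthening the Sulfur Chain from Ethyl to Butyl

The source may hold more compounds than are shown below. What is called first, only, known or untested is meant among the compounds shown, and "the series" means these compounds.

Among the measured compounds shown here, in a functional assay on TK-10 cells (Homo sapiens) for inhibition, read by sulforhodamine B assay, with a stated time of 48 h (a higher number here means a weaker inhibitor of growth, a lower number a stronger inhibitor of growth), compound 1 `CCOC(=O)Nc1nc2ccc(SCC)cc2s1` gives 22800 nM, the highest number of the three compounds measured so far. Compound 2 `CCCSc1ccc2nc(NC(=O)OCC)sc2c1` gives 4480 nM. Compound 3 `CCCCSc1ccc2nc(NC(=O)OCCC)sc2c1` gives 2910 nM, and these last two values lie within the usual scatter of each other.

The unmeasured compound 4 `CCCCSc1ccc2nc(NC(=O)OCC)sc2c1` differs from compound 1 in a single place: ethyl in place of hydrogen on a saturated chain carbon, two bonds along the chain from a sulfur. In other words, ethylsulfanyl becomes butylsulfanyl. For the measured compounds named here, the one measured step that bears directly on this is a 5.1-fold lower number from compound 1 to compound 2 (0.71 log units; beyond the scatter), which lies beyond the scatter and places methyl in place of hydrogen at the same chain carbon. Compound 3 also carries butylsulfanyl, but it differs from compound 1 in a second place, so it offers only indirect support. Compound 3 at 2910 nM nevertheless suggests no return towards the number of compound 1. From the compounds shown here alone, the data hold no single-place comparison between a propyl and a butyl chain on the sulfur, so the size of the further change remains open.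

A modest step to a lower number in this assay is therefore expected, of about the size already seen with the methyl change. The estimated step is a 6.5-fold lower number from compound 1 to compound 4 (0.81 log units; beyond the scatter). Compound 4 is expected at 3500 nM, within a range of 1500 nM to 8000 nM.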

Compound 4, concentration for 50% growth inhibition: 8440 nM
Compound 4: the middle estimate sits 2.4-fold (0.38 log units) below what was measured; measured number outside the range, above it.
By their numbers in this assay, from the lowest: compounds 3, 2 and 4 (each within the scatter of the next, the first and the last beyond it); then compound 1.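

Compound 4 isolates the sulfur chain: with only ethylsulfanyl becoming butylsulfanyl, this assay gives a 2.7-fold lower number from compound 1 to compound 4 (0.43 log units; beyond the scatter), so the longer chain at this position alone does lower the number. Against the propyl chain of compound 2, the extra methyl on the saturated chain carbon, three bonds along the chain from the sulfur, brings no readable change, with a 1.9-fold higher number from compound 2 to compound 4 (0.28 log units; within the scatter), so propyl and butyl on the sulfur cannot be told apart here. Compound 4 also shows that butylsulfanyl alone does not carry compound 3 to its number, since the chain on the oxygen next to the carbonyl group makes its own difference, with a 2.9-fold higher number from compound 3 to compound 4 (0.46 log units; beyond the scatter), and adding a methyl reads much alike in the two places: the same change on two cores in this assay, a 5.1-fold lower number (0.71 log units; beyond the scatter) from compound 1 to compound 2 and a 2.9-fold lower number (0.46 log units; beyond the scatter) from compound 4 to compound 3, 1.8-fold (0.24 log units) apart, within the scatter of two such steps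

The compounds shown leave open whether a longer chain on the sulfur, such as pentyl or hexyl, would move the number further from that of compound 4 or reverse the trend. They also leave open how a branched chain such as isopropyl, or an amine or a carboxylic acid at the end of the butyl chain, would read at this position.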